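Amide Swap on the Shared Diamine Core of Compound 3

The compounds below may be only part of what the source reports. "The series", "measured", "known", "first", "only" and "open" are said of these compounds alone.

Compound 1 `O=C(N[C@H]1CCC[C@H](NC(=O)C2CCCCC2)C1)c1cccc(Cl)c1`: 857 nM
Compound 2 `O=C(N[C@H]1CCC[C@H](NC(=O)c2cccc(Cl)c2)C1)c1cccnc1`: 612 nM
Compound 3 `Cc1cccnc1C(=O)N[C@H]1CCC[C@H](NC(=O)c2cccc(Cl)c2)C1`: 7840 nM

In a functional assay on HEK293 cells for antagonist activity at metabotropic glutamate receptor 5 (Homo sapiens), read by FLIPR and calcium flux (a higher number here means a weaker inhibitor, a lower number a stronger inhibitor), compound 3 `Cc1cccnc1C(=O)N[C@H]1CCC[C@H](NC(=O)c2cccc(Cl)c2)C1` gives 7840 nM, the highest of the three numbers. Its nearest neighbour is compound 1, and the step of a 9.1-fold higher number from compound 1 to compound 3 (0.96 log units; beyond the scatter) is beyond the scatter. Against compound 2 the step of a 13-fold higher number from compound 2 to compound 3 (1.11 log units; beyond the scatter) is larger still. Compound 1 and compound 2 differ by a 1.4-fold lower number from compound 1 to compound 2 (0.15 log units; within the scatter), a step within the scatter.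

Compound 4 `O=C(N[C@H]1CCC[C@H](NC(=O)c2ccccc2F)C1)c1cccc(Cl)c1` carries 2-fluorophenyl in place of 3-methylpyridin-2-yl on a carbonyl carbon. Among the compounds with values here, no measured step swaps two aryl groups of this kind directly, but the steps of a 9.1-fold higher number from compound 1 to compound 3 (0.96 log units; beyond the scatter) and a 13-fold higher number from compound 2 to compound 3 (1.11 log units; beyond the scatter) show that the 3-methylpyridin-2-yl amide stands apart from both the cyclohexyl amide of compound 1 and the pyridin-3-yl amide of compound 2, which sit close together. An aryl amide without that group is therefore expected to fall back toward those two, giving an estimated step of an 8.7-fold lower number from compound 3 to compound 4 (0.94 log units; beyond the scatter) in this assay. Compound 4 is expected to reach about 900 nM, with a range of 300 nM to 3000 nM.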

Compound 4, half-maximal inhibitory concentration: 175 nM
Estimate against measurement, compound 4: 5.1-fold (0.71 log units) above; measured number outside the range, below it.
By their numbers in this assay, from the lowest: compound 4; then compounds 2 and 1 (each within the scatter of the next); then compound 3.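

In this assay, the step to the 2-fluorophenyl amide does more than recover what the 3-methylpyridin-2-yl amide lost: alongside the large step (a 45-fold lower number from compound 3 to compound 4 (1.65 log units; beyond the scatter)), compound 4 also moves past the two earlier amides (a 3.5-fold lower number from compound 2 to compound 4 (0.54 log units; beyond the scatter); a 4.9-fold lower number from compound 1 to compound 4 (0.69 log units; beyond the scatter)). The earlier compounds shown here showed only a loss at this carbonyl carbon, with the cyclohexyl and pyridin-3-yl amides within the scatter of each other, whereas compound 4 shows that the same place can also give a gain and makes compound 4 the strongest inhibitor of the four. No measurement here bears on the reason for this gain.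

The swap from compound 3 to compound 4 exchanges the ring nitrogen, the methyl and the fluorine together, and the compounds shown do not separate these changes. On these data alone, how a plain phenyl or a 2-methoxyphenyl amide would stand at this carbonyl carbon remains open.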